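The source may report more compounds than this note shows. Statements on the series, on what has been measured and on what is new or still open speak of the compounds shown alone.

Measured compounds in a physicochemical assay for solubility, read by nephelometry, measured as kinetic solubility; on this read-out higher numbers stand for higher solubility and lower numbers for lower solubility:
- Compound 1 `COc1cc(OC)cc(C(=O)N[C@H]2CC[C@H](Nc3nc(C)cc(N(C)C)n3)CC2)c1`: a limit of the assay, > 250000 nM.
- Compound 2 `COc1cc(Nc2nc(C)cc(N3CCCCC3)n2)ccc1F`: 160000 nM.
- Compound 3 `CCOC1CCCN(c2cc(C)nc(Nc3ccc(F)c(OC)c3)n2)C1`: a limit of the assay, > 250000 nM.

Among the measured compounds shown here, compound 2 holds the only number reported in this assay; the other two values are limits, and the limit of > 250000 nM in this assay, at which 2 of the 3 values shown sit, marks where those sit. One measured step exists in the set: an at least 1.5-fold higher number from compound 2 to compound 3 (0.19 log units; that floor lies within the scatter), a change on a saturated ring carbon. Compound 4 `COc1cc(Nc2nc(C)cc(NCc3ccccc3)n2)ccc1F` differs from compound 2 in another way: benzylamino in place of piperidin-1-yl on an aromatic carbon. For the measured compounds named here, no measured step touches this aromatic carbon or exchanges a saturated ring for an aromatic one, so the step from compound 2 to compound 3 offers no direct guide; what remains is that compound 2 is the one value that is a number rather than a limit. The step of a 1.5-fold lower number from compound 2 to compound 4 (0.16 log units; within the scatter) is expected to stay within the scatter of this assay. Compound 4 is therefore estimated at 110000 nM in this assay, with a range from 35000 nM to 250000 nM.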

Compound 4, solubility: > 250000 nM
Compound 4 was reported as a limit; the forecaster's own chance of this, stated with the estimate: 20%; at least 2.2-fold (0.35 log units) between middle value and limit.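

Among the compounds shown here, at the aromatic carbon next to the ring nitrogen, benzylamino in place of piperidin-1-yl gives in this assay an at least 1.5-fold higher number from compound 2 to compound 4 (0.19 log units; that floor lies within the scatter) as the first measured step at this position, and the earlier step touched only a saturated ring carbon. Compound 4 gives > 250000 nM as a limit of the assay and not a number, so the true size of this step cannot be read. The change removes the saturated ring and brings in an aromatic ring and a hydrogen-bond donor without a fall in the read-out, and the series now gathers at one ceiling: the limit of > 250000 nM in this assay, at which 3 of the 4 values shown sit.

No order can be set among compound 1, compound 3 and compound 4. On these data alone, how a morpholine ring or a longer chain ending in a carboxylic acid would read at this aromatic carbon stays open.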